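The source may report more compounds than this note shows. Statements on the series, on what has been measured and on what is new or still open speak of the compounds shown alone.

Compound 1 `Cc1ccc(S(=O)(=O)NC(=O)Nc2ccccc2C(=O)/C=C/c2ccc(N(C)C)cc2)cc1` gives 38.1 ug/mL in an ADME assay on the whole organism for cytotoxicity, with Artemia salina as the target, with a stated time of 24 h; a lower number here means that less compound is needed, a higher number that more compound is needed for the effect.
Compound 2 `COc1cccc(/C=C/C(=O)c2ccccc2NC(=O)NS(=O)(=O)c2ccc(C)cc2)c1` gives 23.2 ug/mL.
Compound 3 `Cc1ccc(S(=O)(=O)NC(=O)Nc2ccccc2C(=O)/C=C/c2ccccc2[N+](=O)[O-])cc1` gives 40.1 ug/mL.

Among these three numbers, that of compound 3 is the largest, yet its distance to each of the others is small: the step of a 1.1-fold higher number from compound 1 to compound 3 (0.02 log units; within the scatter) and the step of a 1.7-fold higher number from compound 2 to compound 3 (0.24 log units; within the scatter) both stay within the usual scatter, as does the step of a 1.6-fold lower number from compound 1 to compound 2 (0.22 log units; within the scatter). Compound 4 `Cc1ccc(S(=O)(=O)NC(=O)Nc2ccccc2C(=O)/C=C/c2ccccc2Cl)cc1` has not yet been measured. It differs from compound 3 in one place: chloro in place of nitro on an aromatic carbon. Every measured step exchanged the whole aromatic ring at the end of the double-bonded chain, and none of them moved the number beyond the scatter. The change to compound 4 is smaller still, altering one group on that ring and leaving the rest of the shared core untouched. The expected step is accordingly a 1.1-fold lower number from compound 3 to compound 4 (0.05 log units; within the scatter), which means no movement beyond the scatter. Compound 4 is therefore estimated to give about 36 ug/mL in this assay, with a likely range from 18 ug/mL to 72 ug/mL.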

Compound 4, concentration for half-maximal effect: 12.8 ug/mL
Compound 4: the middle estimate sits 2.8-fold (0.45 log units) above what was measured, and the stated range ends above it.
By their numbers in this assay, from the lowest: compounds 4, 2, 1 and 3 (each within the scatter of the next, the first and the last beyond it).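

In this assay the exchange of one group, chloro in place of nitro on an aromatic carbon ortho to a large group, gives a 3.1-fold lower number from compound 3 to compound 4 (0.50 log units; beyond the scatter) and so passes beyond the scatter, which none of the whole-ring exchanges among compounds 1, 2 and 3 did. Compound 4 does not separate from every earlier compound: a 3.0-fold lower number from compound 1 to compound 4 (0.47 log units; beyond the scatter) also lies beyond the scatter, whereas a 1.8-fold lower number from compound 2 to compound 4 (0.26 log units; within the scatter) stays within it. Nothing measured here bears on why this exchange moves the number.

The compounds shown leave open whether chloro at another place on this ring would give a similar number, and whether fluoro, bromo or methyl at this position would stand nearer to chloro or to nitro. Among these compounds, they also hold only this one pair that differs by a single group on the ring, so it remains open whether the step would recur elsewhere.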